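Benzothiazolylthiomethyl triazoles: swapping the ring-nitrogen substituent

The source may report more compounds than this note shows. Statements on the series, on what has been measured and on what is new or still open speak of the compounds shown alone.

Measured compounds:
compound 1 `Fc1ccc(-n2cc(CSc3nc4ccccc4s3)nn2)cc1` — 77.8%
compound 2 `Brc1ccc(-n2cc(CSc3nc4ccccc4s3)nn2)cc1` — 75%
compound 3 `c1cncc(-n2cc(CSc3nc4ccccc4s3)nn2)c1` — 64%

In a functional assay on the whole organism (strain Albino Wistar) for inhibition, with Rattus norvegicus as the target, read by paw edema, with stated times of 1 h and 3 h, at a dose of 10 mg/kg by the oral route (on this read-out higher numbers stand for more inhibition at the one dose given (going by the name of the read-out) and lower numbers for less inhibition), compound 3 stands lowest of the three numbers. The step of a number 13.8 percentage points lower from compound 1 to compound 3 (beyond the scatter) and the step of a number 11 percentage points lower from compound 2 to compound 3 (beyond the scatter) both lie beyond the scatter and are modest; the step of a number 2.8 percentage points lower from compound 1 to compound 2 (within the scatter) lies within the scatter, so compounds 1 and 2 are not separated.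

Compound 4 `OCC(O)Cn1cc(CSc2nc3ccccc3s2)nn1` is not yet measured. The change is 2,3-dihydroxypropyl in place of pyridin-3-yl on an aromatic nitrogen. Going by the values given here, no measured step exchanges an aromatic group at the ring nitrogen for an open chain; the only steps at that position, from compound 1 to compound 3 and from compound 2 to compound 3, exchange one aromatic ring for another and each gave a modest loss. They bear on the step only in showing that a change at the ring nitrogen has, in those two cases, given a modestly lower number. The direction for compound 4 therefore cannot be read from the data; the expected step of a number 6 percentage points lower from compound 3 to compound 4 (within the scatter) is small and uncertain. For compound 4 the value in this assay is estimated at 58%, expected between 40% and 75%.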

Compound 4, a percentage reported as inhibition, in the whole organism at one dose (the size of the read-out at that dose, not a potency): 56.7%
Compound 4: middle estimate off by 1.3 percentage points, on the high side, and the stated range covers the measured number.
By their numbers in this assay, from the lowest: compounds 4 and 3 (each within the scatter of the next); then compounds 2 and 1 (each within the scatter of the next).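

At the ring nitrogen, an open chain with no ring can stand in for an aromatic group without a clear change from the pyridin-3-yl compound in this assay: the step of a number 7.3 percentage points lower from compound 3 to compound 4 (within the scatter) does not separate the two. The same exchange made against the halogenated phenyl groups gives the step of a number 18.3 percentage points lower from compound 2 to compound 4 (beyond the scatter) and the step of a number 21.1 percentage points lower from compound 1 to compound 4 (beyond the scatter) in this assay, so compounds 1 and 2 stay apart from compound 4 just as they do from compound 3. Among these four compounds, 4-fluorophenyl and 4-bromophenyl are thus the only groups that stand apart, and no compound shown goes against this.

Open, as far as these compounds go, is whether the two hydroxyl groups of the chain matter, as a plain propyl chain would show. From the compounds shown here alone, an unsubstituted phenyl, a chain ending in an amine or a carboxylic acid, and a longer chain also remain open. Nothing measured here gives a cause for these steps.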